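Trimming the Side Chain: From Compound 1 to Compound 4

The source may hold more compounds than are shown below. What is called first, only, known or untested is meant among the compounds shown, and "the series" means these compounds.

The study reports an ADME assay on MDBK cells (Bos taurus) for cytotoxicity, read by MTT assay, with a stated time of 96 h; on this read-out higher numbers stand for lower toxicity in this test and lower numbers for higher toxicity in this test. Compound 1 `CCN(CC)CC(=O)Nc1ccc(-c2nc3cc(C(F)(F)F)ccc3n2C)cc1` gives 57000 nM in this assay. Compound 3 `O=[N+]([O-])c1ccc(-c2nc3cc(C(F)(F)F)ccc3n2C2CCCCC2)cc1` gives 68000 nM in this assay, a number that lies within the scatter of that of compound 1, so the two compounds cannot be told apart on this read-out. Compound 2 `CCC(=O)Nc1ccc(-c2nc3ccccc3[nH]2)cc1` returns only a limit of this assay, > 100000 nM, and not a number; the limit of > 100000 nM in this assay, at which 1 of the 3 values shown sits, is the single such case among the three values shown.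

Compound 4 `Cn1c(-c2ccc(N)cc2)nc2cc(C(F)(F)F)ccc21` has not yet been measured in this assay. It differs from compound 1 in one place: hydrogen in place of ((diethylamino)methyl)carbonyl on a nitrogen on an aromatic ring. Among the measured compounds shown here, no pair of measured compounds differs in this way, so no measured step tells the size of this change. All three compounds shown sit at weak toxicity, and the step from compound 1 to compound 4 is expected to be small, a 1.1-fold higher number from compound 1 to compound 4 (0.06 log units; within the scatter), within the scatter rather than beyond it. Compound 4 is therefore estimated at 65000 nM in this assay, with a likely range from 30000 nM to 150000 nM.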

Compound 4, half-maximal cytotoxic concentration: 74000 nM
Compound 4: the middle estimate sits 1.1-fold (0.06 log units) below what was measured, and the stated range covers the measured number.
By their numbers in this assay, from the lowest: compounds 1, 3 and 4 (each within the scatter of the next). At a limit, above all of these: compound 2.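

In this assay, putting hydrogen in place of ((diethylamino)methyl)carbonyl on the nitrogen on the aromatic ring gives a 1.3-fold higher number from compound 1 to compound 4 (0.11 log units; within the scatter). Among the compounds shown here, this is the only measured step at this position, and it shows that the whole side chain can be removed, leaving a plain amino group, without a difference that this read-out can detect. Compound 2 alone stays a limit and not a number, so the step from the side chain to hydrogen rests on two true numbers, and no limit enters it: the limit of > 100000 nM in this assay, at which 1 of the 4 values shown sits.

The compounds shown leave open whether a different group on this nitrogen, such as a short acetyl or a carboxylic acid chain, would also stay within the scatter of compound 4. They also leave open whether the same holds when the methyl on the shared core is replaced by a cyclohexyl.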